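The source may hold more compounds than are shown below. What is called first, only, known or untested is meant among the compounds shown, and "the series" means these compounds.

Compound 2 `COC(=O)C1=C(C)N=C(C)/C(=C(/O)OC)C1c1ccccc1OCc1nonc1C(N)=O` is the weaker of the two measured compounds: in an assay on Cortex for displacement of a labelled ligand from Voltage-dependent L-type calcium channel subunit alpha-1D (Rattus norvegicus) (on this read-out lower numbers stand for stronger inhibition and higher numbers for weaker inhibition), compound 2 gives 880 nM, while compound 1 `COC(=O)C1=C(C)N=C(C)/C(=C(/O)OC)C1c1ccccc1OCc1c(C)no[n+]1[O-]` gives 72 nM. Compound 3 `COC(=O)C1=C(C)N=C(C)/C(=C(/O)OC)C1c1ccccc1OCc1c(C#N)no[n+]1[O-]` has not yet been measured. Going by the values given here, the change from compound 2 to compound 3 is a group of 8 heavy atoms (3 carbon, 3 nitrogen, 2 oxygen; one five-membered aromatic ring with 3 hetero atoms) in place of a group of 8 heavy atoms (3 carbon, 3 nitrogen, 2 oxygen; one five-membered aromatic ring with 3 hetero atoms), on a saturated chain carbon bound to an oxygen on an aromatic ring; the group that leaves is the same one whose arrival caused the only measured step, a 12-fold higher number from compound 1 to compound 2 (1.09 log units; beyond the scatter). The entering group shares with the group of compound 1 a ring with three hetero atoms and no hydrogen-bond donor, but carries a triple bond outside aromatic rings in place of a methyl, a detail on which the data are silent. Undoing the step that weakened compound 2 should bring the number down, though not necessarily all the way back. Compound 3 is therefore expected to show a step of a 5.9-fold lower number from compound 2 to compound 3 (0.77 log units; beyond the scatter), with an estimate of 150 nM and a likely range from 50 nM to 450 nM.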

Compound 3, half-maximal inhibitory concentration: 67 nM
For compound 3 the middle estimate is 2.2-fold (0.35 log units) above the measured one, within the range that was stated.
By their numbers in this assay, from the lowest: compounds 3 and 1 (each within the scatter of the next); then compound 2.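

In this assay, replacing the 4-carbamoyl-1,2,5-oxadiazol-3-yl group with the cyano-bearing ring gives a 13-fold lower number from compound 2 to compound 3 (1.12 log units; beyond the scatter) and so shows that the weak result of compound 2 is not shared by every group of this size at this place. The step of cyano in place of methyl on an aromatic carbon is a 1.1-fold lower number from compound 1 to compound 3 (0.03 log units; within the scatter) and therefore shows no measurable difference between these two groups in this assay. Among these three compounds, the group with a hydrogen-bond donor is also the one that gives the weak number, but three compounds cannot show that the donor is responsible.

On these data alone, whether an amine or a carboxylic acid on that aromatic carbon would match cyano and methyl remains open. The data do not tell what lies behind the difference between these groups. No supporting data are available.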